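The compounds below may be only part of what the source reports. "The series", "measured", "known", "first", "only" and "open" are said of these compounds alone.

In a functional assay on LNCaP cells (Homo sapiens) for antiproliferative activity (on this read-out higher numbers stand for weaker inhibition and lower numbers for stronger inhibition), compound 1 `Cn1ncc(Cl)c1-c1cc(C(=O)N[C@@H]2CN[C@H](CCNS(C)(=O)=O)C[C@H]2c2ccc(F)c(F)c2)oc1Cl` gives 50 nM.
Compound 2 `CN(C)CC[C@@H]1C[C@@H](c2ccc(Cl)c(Cl)c2)[C@H](NC(=O)c2cc(-c3c(Cl)cnn3C)c(Cl)o2)CN1` gives 1930 nM.
Compound 3 `CC(=O)OCC[C@@H]1C[C@@H](c2ccc(F)c(F)c2)[C@H](NC(=O)c2cc(-c3c(Cl)cnn3C)c(Cl)o2)CN1` has no reported result, entered as "not determined" (no result reported).

Of the two numbers available, compound 2 stands highest at 1930 nM. Compound 1 gives 50 nM. The gap between these two compounds lies beyond the scatter. Among the compounds with values here, those two compounds differ in more than one place, and no measured pair here differs in one place only, so the data offer no direct guide to a single change.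

Compound 4 `Cn1ncc(Cl)c1-c1cc(C(=O)N[C@@H]2CN[C@H](CC(=O)NC3CCC3)C[C@H]2c2ccc(Cl)c(Cl)c2)oc1Cl` is reached from compound 2 through one change: cyclobutylcarbamoyl in place of (dimethylamino)methyl on a saturated chain carbon bound to a saturated ring carbon. In words, cyclobutylcarbamoyl takes the place of (dimethylamino)methyl on a saturated chain carbon bound to a saturated ring carbon.

Compound 1 at 50 nM also lacks the dimethylamino group, which gives a tentative reason to expect stronger inhibition. The estimated change is a 9.7-fold lower number from compound 2 to compound 4 (0.98 log units; beyond the scatter) and is expected to lie beyond the scatter. For compound 4 the estimated value is 200 nM with an expected range from 40 nM to 900 nM in this estimate.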

Compound 4, half-maximal inhibitory concentration: 80 nM
The estimate for compound 4 lay 2.5-fold (0.40 log units) above the measured number; measured number inside the range.
By their numbers in this assay, from the lowest: compounds 1 and 4 (each within the scatter of the next); then compound 2.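

Within the data shown here, this is the only step here that changes a single place, and it shows that in this assay the group on a saturated chain carbon bound to a saturated ring carbon can strongly shift the result: putting cyclobutylcarbamoyl in place of (dimethylamino)methyl gives a 24-fold lower number from compound 2 to compound 4 (1.38 log units; beyond the scatter). The entering group differs in several ways at once, bringing a hydrogen-bond donor, a double bond outside aromatic rings and a four-membered carbon ring, so this one step cannot show which of these goes with the lower number. No measurement offered here accounts for the step.

A simple methyl amide, a carboxylic acid or a primary amine at this place would help separate the contribution of the amide from that of the cyclobutyl ring. As far as these compounds go, whether the step keeps its size on the core of compound 1 also remains open.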